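The compounds below may be only part of what the source reports. "The series", "measured", "known", "first", "only" and "open" are said of these compounds alone.

Of the compounds shown here, three carry numbers so far. Compound 1 `O=c1ccn([C@@H]2O[C@H](COP(=O)(O)OP(=O)(O)O)[C@@H](O)[C@H]2O)c(SCCc2ccccc2)n1` reaches only a limit in an in vitro functional assay on 1321-N1 cells for agonist activity at P2Y purinoceptor 4 (Homo sapiens), read by scintillation proximity assay and inositol phosphate accumulation (on this read-out higher numbers stand for an effect only at larger amounts of compound and lower numbers for an effect already at smaller amounts), namely >= 100000 nM, which is the limit of >= 100000 nM in this assay, at which 1 of the 3 values shown sits. Compound 2 `COc1nc(=O)ccn1[C@@H]1O[C@H](COP(=O)(O)OP(=O)(O)O)[C@@H](O)[C@H]1O` gives 4490 nM in this assay, and compound 3 `CCCSc1nc(=O)ccn1[C@@H]1O[C@H](COP(=O)(O)OP(=O)(O)O)[C@@H](O)[C@H]1O` gives 4900 nM. Compound 3 thus holds the highest of the two numbers, with compound 2 nearest: a 1.1-fold higher number from compound 2 to compound 3 (0.04 log units; within the scatter), so the two cannot be told apart. The other measured steps are both large: an at least 22-fold lower number from compound 1 to compound 2 (1.34 log units; beyond the scatter) and an at least 20-fold lower number from compound 1 to compound 3 (1.30 log units; beyond the scatter).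

Compound 4 `O=c1ccn([C@@H]2O[C@H](COP(=O)(O)OP(=O)(O)O)[C@@H](O)[C@H]2O)c(SCc2ccccc2)n1` awaits measurement in this assay. It differs from compound 3 by phenyl in place of ethyl on a saturated chain carbon bound to a sulfur. The step that bears on it most is an at least 20-fold lower number from compound 1 to compound 3 (1.30 log units; beyond the scatter), where taking the phenyl off the saturated chain two bonds along from the sulfur moved the number off the limit by a large margin. Compound 4 puts a phenyl back on the saturated chain carbon bound to the sulfur, so the step is expected to run the other way and to be large: a 6.1-fold higher number from compound 3 to compound 4 (0.79 log units; beyond the scatter). The number may again be reported only as a limit. Compound 4 is estimated at 30000 nM, with a range from 8000 nM to 100000 nM.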

Compound 4, half-maximal effective concentration: 5980 nM
Compound 4: middle estimate off by 5.0-fold (0.70 log units), on the high side, and the stated range ends above it.
By their numbers in this assay, from the lowest: compounds 2, 3 and 4 (each within the scatter of the next). At a limit, above all of these: compound 1.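

In this assay, benzylsulfanyl on the aromatic carbon cannot be told apart from the two smaller groups: a 1.2-fold higher number from compound 3 to compound 4 (0.09 log units; within the scatter) and a 1.3-fold higher number from compound 2 to compound 4 (0.12 log units; within the scatter). A phenyl on the saturated chain carbon bound to a sulfur is thus compatible with a measurable number, and among the compounds shown the large step is confined to the change from phenethylsulfanyl to benzylsulfanyl, an at least 16-fold lower number from compound 1 to compound 4 (1.22 log units; beyond the scatter), so compound 1 alone stands apart from compounds 2, 3 and 4. The value of compound 1 is a limit and not a number, so that step has no exact size: the limit of >= 100000 nM in this assay, at which 1 of the 4 values shown sits.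

As far as these compounds go, it stays open whether a butylsulfanyl chain without a ring would read like compound 3 or like compound 1, so chain length and the phenyl cannot yet be separated as the source of the large step. Also open, from the compounds shown here alone, is how an amine or a carboxylic acid at the end of the chain, or a chloro group on the phenyl of compound 4, would read in this assay.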